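Chloro for methoxy on the shared core, second instance

The source may report more compounds than this note shows. Statements on the series, on what has been measured and on what is new or still open speak of the compounds shown alone.

Measured so far:
compound 1 `COc1ccc2c(c1)nc(/C=C/C(=O)/C=C/c1ccc(O)c(OC)c1)n2C` gives 12700 nM in a functional assay on NCI-H460 cells (Homo sapiens) for cytotoxicity, read by MTT assay, with a stated time of 48 h; on this read-out higher numbers stand for weaker inhibition and lower numbers for stronger inhibition
compound 2 `COc1cc(/C=C/C(=O)/C=C/c2nc3cc(Cl)ccc3n2C)ccc1O` gives 8900 nM in this assay
compound 3 `COc1ccc2c(c1)nc(/C=C/C(=O)/C=C/c1ccc(OC)c(O)c1)n2C` gives 11700 nM in this assay

Compound 2 differs from compound 1 by chloro in place of methoxy on an aromatic carbon, and that step measures a 1.4-fold lower number from compound 1 to compound 2 (0.15 log units; within the scatter). Compound 3 differs from compound 1 in its core by 3-hydroxy-4-methoxyphenyl in place of 4-hydroxy-3-methoxyphenyl on a double-bonded chain carbon bound to a double-bonded chain carbon, the step being a 1.1-fold lower number from compound 1 to compound 3 (0.04 log units; within the scatter). All three values sit within the usual scatter of one another.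

Compound 4 `COc1ccc(/C=C/C(=O)/C=C/c2nc3cc(Cl)ccc3n2C)cc1O` is not yet measured. It carries chloro in place of methoxy on an aromatic carbon relative to compound 3; the place is the same word for word as in the earlier instance, so the change is the same, seen once so far.

The step from compound 3 to compound 4 in this assay is expected to be about a 1.4-fold lower number from compound 3 to compound 4 (0.14 log units; within the scatter), resting on the earlier 1.4-fold lower number from compound 1 to compound 2 (0.15 log units; within the scatter). Compound 4 is therefore estimated at 8500 nM, expected to fall between 4500 nM and 16000 nM.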

Compound 4, half-maximal inhibitory concentration: 7300 nM
Compound 4: the middle estimate sits 1.2-fold (0.07 log units) above what was measured; the range from low to high includes it.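

Chloro in place of methoxy on an aromatic carbon gives a 1.6-fold lower number from compound 3 to compound 4 (0.20 log units; within the scatter) in this assay, and this step matches the earlier one on the other core: the same change on two cores in this assay, a 1.4-fold lower number (0.15 log units; within the scatter) from compound 1 to compound 2 and a 1.6-fold lower number (0.20 log units; within the scatter) from compound 3 to compound 4, 1.1-fold (0.05 log units) apart, within the scatter of two such steps. The change therefore carries across these two cores with no visible difference in size. It does not show that chloro gives a real gain over methoxy, as each step lies within the scatter, and the test is narrow: the two cores differ only in 3-hydroxy-4-methoxyphenyl against 4-hydroxy-3-methoxyphenyl.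

Open, going by these compounds, is whether an amine, a carboxylic acid or a longer chain at this aromatic carbon would move the number beyond the scatter. Also open, on these data alone, is whether the step holds on a core carrying neither of those two phenyl groups.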